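Fluorophenyl amides on a shared core: maximal response

The source may hold more compounds than are shown below. What is called first, only, known or untested is meant among the compounds shown, and "the series" means these compounds.

Measured so far:
Compound 1 `O=C(c1ccc(F)cc1)N1CCc2nc(COc3ccncc3)oc2C1` — 71%
Compound 2 `O=C(c1cccc(F)c1)N1CCc2nc(COc3cccc(F)c3)oc2C1` — 75%
Compound 3 `O=C(c1cccc(F)c1F)N1CCc2nc(COc3cccc(F)c3)oc2C1` — 72%

In a functional assay on HEK293 cells for positive allosteric modulation of metabotropic glutamate receptor 5 (Homo sapiens), read by calcium flux (on this read-out lower numbers stand for smaller maximal responses and higher numbers for larger maximal responses), compound 3 gives 72%, the second highest of the three numbers. Compound 1 gives 71% and compound 2 gives 75%, both within the scatter of compound 3. Compound 4 `O=C(c1cc(F)cc(F)c1)N1CCc2nc(COc3cccc(F)c3)oc2C1` differs from compound 3 by 3,5-difluorophenyl in place of 2,3-difluorophenyl on a carbonyl carbon. For the measured compounds named here, the only measured step at the amide aryl group is a number 3 percentage points lower from compound 2 to compound 3 (within the scatter), which lies within the scatter, and all three numbers sit close together. No change beyond the scatter is therefore expected in this assay for compound 4, whose estimate is 72%, with a range from 62% to 82%. The expected step is no change at the digits printed from compound 3 to compound 4 (within the scatter).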

Compound 4, largest response reached (reported as percent of maximum), in percent of the reference or control that the assay uses: 42%
The estimate for compound 4 lay 30 percentage points above the measured number; measured number outside the range, below it.
By their numbers in this assay, from the lowest: compound 4; then compounds 1, 3 and 2 (each within the scatter of the next).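

In this assay, the amide aryl group proves sensitive to how its two fluoro groups are arranged: 3,5-difluorophenyl in place of 2,3-difluorophenyl on a carbonyl carbon gives a number 30 percentage points lower from compound 3 to compound 4 (beyond the scatter), with the same atoms in both groups. Adding one fluoro in place of hydrogen can give a number 3 percentage points lower from compound 2 to compound 3 (within the scatter) or a number 33 percentage points lower from compound 2 to compound 4 (beyond the scatter), so the outcome depends on where the fluoro stands, not merely on its presence. Nothing available explains the drop. On these data alone, whether 3,5-dichlorophenyl or 3,5-dimethoxyphenyl on the same carbonyl carbon would also lower the maximal response remains open.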